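The source may hold more compounds than are shown below. What is called first, only, known or untested is meant among the compounds shown, and "the series" means these compounds.

Working notes on a small set of bis-sulfonamides sharing one core, each carrying two sulfonyl aryl groups on sulfonamide nitrogens. Two members have numbers in an assay for inhibition of HSP60/HSP10 (Homo sapiens), with a stated time of 60 min; on this read-out higher numbers stand for weaker inhibition and lower numbers for stronger inhibition. Compound 1, `O=S(=O)(Nc1ccc(-c2nc3cc(NS(=O)(=O)c4cccc(C(F)(F)F)c4)ccc3o2)cc1)c1cccc(C(F)(F)F)c1`, carries the same 3-(trifluoromethyl)phenyl on both sulfonyl sulfurs; in this assay compound 1 gives 58000 nM. Compound 2, `O=[N+]([O-])c1cc(S(=O)(=O)Nc2ccc3oc(-c4ccc(NS(=O)(=O)c5ccc(Cl)s5)cc4)nc3c2)ccc1Cl`, carries a 4-chloro-3-nitrophenyl on one sulfonyl sulfur and a 5-chlorothiophen-2-yl on the other; in this assay compound 2 gives 1000 nM. Compound 2 holds the lower of the two numbers, and the gap to compound 1 lies well beyond the scatter; since the two differ in both sulfonyl aryl groups, no single step can be read from them.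

The next member, compound 3, `O=S(=O)(Nc1ccc2oc(-c3ccc(NS(=O)(=O)c4ccc(Cl)s4)cc3)nc2c1)c1cccc(C(F)(F)F)c1`, keeps the 5-chlorothiophen-2-yl sulfonyl of compound 2 and changes only the other sulfonyl aryl: 3-(trifluoromethyl)phenyl in place of 4-chloro-3-nitrophenyl on a sulfonyl sulfur. This brings one sulfonyl aryl of compound 3 into line with compound 1, whose number in this assay is 58000 nM, so a move toward weaker inhibition is expected, of a size beyond the scatter but not reaching compound 1. The expected step from compound 2 to compound 3 is a 6.0-fold higher number from compound 2 to compound 3 (0.78 log units; beyond the scatter). Compound 3 is estimated at 6000 nM, with a range from 1500 nM to 25000 nM.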

Compound 3, half-maximal inhibitory concentration: 5000 nM
For compound 3 the middle estimate is 1.2-fold (0.08 log units) above the measured one; the measured number falls inside the stated range.
By their numbers in this assay, from the lowest: compound 2; then compound 3; then compound 1.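

With compound 3, each sulfonyl aryl can be read on its own in this assay. With the 5-chlorothiophen-2-yl held fixed, 3-(trifluoromethyl)phenyl in place of 4-chloro-3-nitrophenyl gives a 5.0-fold higher number from compound 2 to compound 3 (0.70 log units; beyond the scatter) on the shared core, so the choice of aryl at this sulfonyl sulfur shifts the number beyond the scatter, even though both groups have the same heavy-atom count and a six-membered aromatic carbon ring. With 3-(trifluoromethyl)phenyl held fixed on that sulfur, 5-chlorothiophen-2-yl in place of 3-(trifluoromethyl)phenyl on the other sulfonyl sulfur gives a 12-fold lower number from compound 1 to compound 3 (1.06 log units; beyond the scatter) in the same direction as the lower numbers of the set, and no measurement at hand bears on why either step occurs.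

The compounds shown leave open whether the step from 4-chloro-3-nitrophenyl rests on its chlorine, its nitro group or the two together. They also leave open how an amine or a carboxylic acid on the phenyl ring at either sulfonyl sulfur would read, and whether the two sulfonyl aryl groups would give the same number with their places exchanged.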